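Methyl step on the core of compound 1

The source may hold more compounds than are shown below. What is called first, only, known or untested is meant among the compounds shown, and "the series" means these compounds.

In a functional assay on MCF7 cells (Homo sapiens) for inhibition, with a stated time of 48 h (on this read-out higher numbers stand for weaker inhibition and lower numbers for stronger inhibition), compound 1 (`COc1cc(Sc2c[nH]c3ccccc23)cc(OC)c1OC`) gives 34 nM. Compound 2 (`COc1cc(Sc2c(C)[nH]c3ccccc23)cc(OC)c1OC`) gives 46 nM and compound 3 (`COc1cc(Sc2c[nH]c3ccc(I)cc23)cc(OC)c1OC`) gives 68 nM. Both stay within the scatter of compound 1, so its standing among the three is not separated from theirs.

Compound 4 (`COc1cc(Sc2c[nH]c3ccc(C)cc23)cc(OC)c1OC`) is not yet measured. It differs from compound 1 by methyl in place of hydrogen on an aromatic carbon, on a six-membered aromatic ring of carbon only, part of a fused system of two rings.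

Within the data shown here, two measured steps bear on this change. Compound 2 brings the same group to another carbon, with a 1.4-fold higher number from compound 1 to compound 2 (0.13 log units; within the scatter). Compound 3 brings iodo to the carbon that carries the methyl in compound 4, with a 2.0-fold higher number from compound 1 to compound 3 (0.30 log units; within the scatter). Both steps lie within the scatter, though both run towards a higher number, so no step beyond the scatter is expected in this assay. The expected change is a 1.4-fold higher number from compound 1 to compound 4 (0.15 log units; within the scatter). For compound 4 the estimate is 48 nM, with an expected range of 22 nM to 105 nM.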

Compound 4, half-maximal inhibitory concentration: 16 nM
Compound 4: middle estimate off by 3.0-fold (0.48 log units), on the high side, outside the stated range (below it).
By their numbers in this assay, from the lowest: compound 4; then compounds 1, 2 and 3 (each within the scatter of the next).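

In this assay, this carbon on the six-membered aromatic ring is the only place among those shown where a step from compound 1 passes the scatter, and it runs to a lower number: a 2.1-fold lower number from compound 1 to compound 4 (0.33 log units; beyond the scatter). This carbon does not respond alike to every group: iodo stays within the scatter of hydrogen, with a 2.0-fold higher number from compound 1 to compound 3 (0.30 log units; within the scatter), whereas exchanging iodo for methyl gives a 4.3-fold lower number from compound 3 to compound 4 (0.63 log units; beyond the scatter). No measurement shown here accounts for the difference between methyl and iodo on this carbon.

Open, from the compounds shown here alone, is whether a longer chain such as ethyl keeps the lower number at this carbon, or whether the result is confined to methyl. An amine or a carboxylic acid on the same carbon would show how far the position tolerates groups other than methyl and iodo.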